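Small alkyl and alkoxy variations on a shared amide core

This account rests on a few compounds, and the source may have more. Where it says the series, first, only, none or still open, it means among the compounds named here.

Three compounds of this series have been run in a functional assay on Hep 3B2 cells (Homo sapiens) for antiproliferative activity, read by MTT assay, with a stated time of 24 h, tested at 0.05 ug/mL; on this read-out higher numbers stand for a stronger effect at the one concentration tested and lower numbers for a weaker effect. Compound 1 `Cc1ccc2nc(C(=O)Nc3c(F)cc(-c4cccc(F)c4)cc3F)c(C)c(O)c2c1` gives 1.52% in this assay. Compound 2 `CCc1ccc2nc(C(=O)Nc3c(F)cc(-c4cccc(F)c4)cc3F)c(C)c(O)c2c1` gives 5.62% in this assay. The structural change between them is hydrogen in place of methyl on a saturated chain carbon bound to an aromatic carbon, and the step that goes with it is a number 4.1 percentage points lower from compound 2 to compound 1 (within the scatter). Compound 3 `CCOc1ccc2nc(C(=O)Nc3c(F)cc(-c4cccc(F)c4)cc3F)c(C)c(C(=O)O)c2c1` gives 0.98% in this assay; the difference between the core of compound 3 and the core of compound 2 is not broken down here. For the measured compounds named here, all three numbers lie within the scatter of one another, so no ordering among them can be read, and every compound so far sits near the bottom of the inhibition scale at the single concentration used.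

Compound 4 `COc1ccc2nc(C(=O)Nc3c(F)cc(-c4cccc(F)c4)cc3F)c(C)c(C(=O)O)c2c1` has not yet been measured. Relative to compound 3 the change is hydrogen in place of methyl on a saturated chain carbon bound to an oxygen on an aromatic ring. Going by the values given here, this is the same kind of change as the one seen between compound 2 and compound 1, but not the same: there the place was a saturated chain carbon bound to an aromatic carbon, here it is a saturated chain carbon bound to an oxygen on an aromatic ring. The earlier step was a number 4.1 percentage points lower from compound 2 to compound 1 (within the scatter), within the scatter.

The step from compound 3 to compound 4 is expected to be a number 0.5 percentage points higher from compound 3 to compound 4 (within the scatter), resting on compound 3 at 0.98% and on the earlier step of a number 4.1 percentage points lower from compound 2 to compound 1 (within the scatter), neither of which shows room for a large move. Compound 4 is therefore expected to give about 1.5% in this assay, with a range estimated from -4% to 7%.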

Compound 4, a percentage reported as inhibition, at one concentration (the size of the read-out at that concentration, not a potency): -0.66%
For compound 4 the middle estimate is 2.2 percentage points above the measured one, within the range that was stated.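

In this assay, shortening ethoxy to methoxy gives a number 1.6 percentage points lower from compound 3 to compound 4 (within the scatter). Set beside the ethyl to methyl change on the other core, this step cannot be told apart from the earlier one: the same change on two cores in this assay, a number 4.1 percentage points lower (within the scatter) from compound 2 to compound 1 and a number 1.6 percentage points lower (within the scatter) from compound 3 to compound 4, 2.5 percentage points apart, within the scatter of two such steps. From the compounds shown here alone, this shows only that, on both cores, removing the terminal methyl leaves the read-out within the scatter, at the low end of the inhibition scale and at a single concentration; it does not show that the change has the same effect on both cores, since neither step can be told from zero, the two places differ in what the chain is bound to, and a transfer of the change to a compound with a clear effect remains untested by these numbers.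

The compounds shown leave open whether a longer chain such as propoxy, or an amine in the place of the ethoxy, would give a step beyond the scatter in this assay. They also leave open how the hydroxy and carboxylic acid cores compare with everything else held equal, as every pair that carries the two groups also differs in a second place.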